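Compound 3 to compound 4: one group exchanged

This account rests on a few compounds, and the source may have more. Where it says the series, first, only, none or still open, it means among the compounds named here.

Measured in a functional assay on SW-620 cells (Homo sapiens) for cytotoxicity, read by MTT assay, with stated times of 4 h and 72 h, tested at 2 uM; a lower number here means a stronger inhibitor, a higher number a weaker inhibitor:
Compound 1 `COc1ccc(/C=C/C(=O)c2ccc(Nc3cc(C)nc4nc(SCc5nc6ccccc6[nH]5)nn34)cc2)cc1F`: 140 nM
Compound 2 `Cc1cc(Nc2ccc(C(=O)/C=C/c3ccccc3)cc2)n2nc(SCc3nc4ccccc4[nH]3)nc2n1`: 130 nM
Compound 3 `Cc1cc(Nc2ccc(C(=O)/C=C/c3ccc(-n4cccn4)cc3)cc2)n2nc(SCc3nc4ccccc4[nH]3)nc2n1`: 340 nM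

Compound 3 has the highest number of the three in this assay, and its steps to both other compounds lie beyond the scatter. Compound 4 `Cc1cc(Nc2ccc(C(=O)/C=C/c3cccc(Cl)c3)cc2)n2nc(SCc3nc4ccccc4[nH]3)nc2n1` has not yet been measured. It differs from compound 3 as follows: 3-chlorophenyl in place of 4-(1H-pyrazol-1-yl)phenyl on a double-bonded chain carbon bound to a double-bonded chain carbon. The 3-chlorophenyl group thus takes the place of 4-(1H-pyrazol-1-yl)phenyl on a double-bonded chain carbon bound to a double-bonded chain carbon.

Within the data shown here, three measured steps bear on this exchange. Placing 1H-pyrazol-1-yl in place of hydrogen on an aromatic carbon gave a 2.6-fold higher number from compound 2 to compound 3 (0.42 log units; beyond the scatter). The exchange of 3-fluoro-4-methoxyphenyl for 4-(1H-pyrazol-1-yl)phenyl gave a 2.4-fold higher number from compound 1 to compound 3 (0.39 log units; beyond the scatter). Exchanging 3-fluoro-4-methoxyphenyl for phenyl gave only a 1.1-fold lower number from compound 1 to compound 2 (0.03 log units; within the scatter), so these two groups do not separate in this assay. Among the measured compounds shown here, no measured compound carries chlorine, which leaves the estimate resting on these two neighbours. A modest step toward a lower number is therefore expected, namely a 2.3-fold lower number from compound 3 to compound 4 (0.36 log units; beyond the scatter). Compound 4 is estimated at 150 nM, with an expected range of 70 nM to 320 nM.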

Compound 4, half-maximal inhibitory concentration: 400 nM
Estimate against measurement, compound 4: 2.7-fold (0.43 log units) below; measured number above the stated range.
By their numbers in this assay, from the lowest: compounds 2 and 1 (each within the scatter of the next); then compounds 3 and 4 (each within the scatter of the next).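

In this assay, the 3-chlorophenyl group on a double-bonded chain carbon bound to a double-bonded chain carbon does not keep the level of the two earlier groups: chloro in place of hydrogen on an aromatic carbon gives a clear step (a 3.1-fold higher number from compound 2 to compound 4 (0.49 log units; beyond the scatter)), and 3-chlorophenyl in place of 3-fluoro-4-methoxyphenyl gives a similar one (a 2.9-fold higher number from compound 1 to compound 4 (0.46 log units; beyond the scatter)). The exchange of 4-(1H-pyrazol-1-yl)phenyl for 3-chlorophenyl (a 1.2-fold higher number from compound 3 to compound 4 (0.07 log units; within the scatter)) stays within the scatter, so a group of 7 heavy atoms without hydrogen-bond acceptors does not separate here from one of 11 heavy atoms with 2 acceptors. The four compounds thus fall into two levels, but a substituent on the phenyl ring does not by itself lead to the higher numbers, as compound 1 goes against that reading, and no measurement available here explains the split between the two levels.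

On these data alone, what remains open is whether the step of compound 4 belongs to the chlorine itself or to its place on the ring, which a 4-chlorophenyl or 3-fluorophenyl group at this carbon would address. As far as these compounds go, it is equally open how this assay would respond to an amine or a carboxylic acid on the same ring.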